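The source may report more compounds than this note shows. Statements on the series, on what has been measured and on what is new or still open speak of the compounds shown alone.

In a functional assay on HL-60 cells (Homo sapiens) for inhibition, read by CCK-8 assay, with a stated time of 48 h (a higher number here means a weaker inhibitor, a lower number a stronger inhibitor), compound 1 (`O=C(NCCNS(=O)(=O)c1ccc(-c2ccccc2O[C@H]2CC[C@H](O)CC2)s1)Nc1cc(C(F)(F)F)cc(C(F)(F)F)c1`) gives 7100 nM and compound 2 (`Cc1ccc(-c2ccsc2S(=O)(=O)NCCNC(=O)Nc2cc(C(F)(F)F)cc(C(F)(F)F)c2)c(Oc2ccc(O)c(O)c2)c1`) gives 3700 nM. Among the compounds with values here, these two numbers lie within the usual scatter of repeated measurements, so compound 2 cannot be told apart from compound 1, the only other compound measured so far.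

Compound 3 (`O=C(NCCNS(=O)(=O)c1sccc1-c1ccccc1Oc1ccc(O)c(O)c1)Nc1cc(C(F)(F)F)cc(C(F)(F)F)c1`) comes from compound 2 by a single structural change: hydrogen in place of methyl on an aromatic carbon. Put simply, this is hydrogen in place of methyl on an aromatic carbon. Within the data shown here, no measured pair of compounds shows what such a change does here, so the data give no direction for it. No step beyond the scatter is therefore expected in this assay, and the expectation starts from compound 2 at 3700 nM. The expected size of the change is a 1.1-fold higher number from compound 2 to compound 3 (0.03 log units; within the scatter). For compound 3 the estimated value is 4000 nM, with an expected range from 1500 nM to 10000 nM.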

Compound 3, half-maximal inhibitory concentration: 5700 nM
Beside the measured number, compound 3's estimate is 1.4-fold (0.15 log units) below it; measured number inside the range.
By their numbers in this assay, from the lowest: compounds 2, 3 and 1 (each within the scatter of the next).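

In this assay, placing hydrogen where the methyl sat, on the aromatic carbon meta to the 3,4-dihydroxyphenoxy group and para to a large group, gives a 1.5-fold higher number from compound 2 to compound 3 (0.19 log units; within the scatter). Within the data shown here, this is the first direct reading of this change, and it leaves compound 2 and compound 3 indistinguishable, so the methyl is not needed to keep inhibition at this level in this assay. Nothing measured here offers an explanation for this result.

With only methyl and hydrogen shown at this position, it remains open whether a different group, such as a chlorine atom, a methoxy group, an amine or a carboxylic acid, would move the number beyond the scatter. Going by these compounds, compound 1 differs from compound 2 and compound 3 in more than one place, so the contribution of the 3,4-dihydroxyphenoxy group itself also remains open.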